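Swapping the aryl group on the hydrazone of a shared core

The source may hold more compounds than are shown below. What is called first, only, known or untested is meant among the compounds shown, and "the series" means these compounds.

Measured so far in a functional assay on HCT-116 cells (Homo sapiens) for antiproliferative activity, read by MTT assay; on this read-out lower numbers stand for stronger inhibition and higher numbers for weaker inhibition:
Compound 1, `Cn1c(=O)c(=O)n(C2CCCC2)c2nc(N/N=C/c3ccc(S(C)(=O)=O)cc3)ncc21`, gives 86600 nM.
Compound 2, `Cn1c(=O)c(=O)n(C2CCCC2)c2nc(N/N=C/c3ccc(O)c(F)c3)ncc21`, gives 59300 nM.
Compound 3, `Cn1c(=O)c(=O)n(C2CCCC2)c2nc(N/N=C/c3cccs3)ncc21`, gives 52600 nM.

All three compounds share one core and differ only in the aryl group on a carbon with a double bond to nitrogen. Compound 2 holds the second highest of the three numbers; its nearest neighbour is compound 3, its furthest is compound 1, and both gaps sit within the scatter, so no order among the three can be claimed.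

Compound 4, `Cn1c(=O)c(=O)n(C2CCCC2)c2nc(N/N=C/c3cc([N+](=O)[O-])ccc3Cl)ncc21`, has not yet been measured. It differs from compound 2 as follows: 2-chloro-5-nitrophenyl in place of 3-fluoro-4-hydroxyphenyl on a carbon with a double bond to nitrogen.

Within the data shown here, three measured steps bear on this kind of change, since each swaps one aryl group for another at the same place. They are a 1.5-fold lower number from compound 1 to compound 2 (0.16 log units; within the scatter), a 1.6-fold lower number from compound 1 to compound 3 (0.22 log units; within the scatter) and a 1.1-fold lower number from compound 2 to compound 3 (0.05 log units; within the scatter). None of them moved the number beyond the scatter, whether the group carried a hydroxyl, a fluorine, a methylsulfonyl or a sulfur-containing ring.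

On that basis no step beyond the scatter is expected for compound 4, and the estimated step is a 1.0-fold higher number from compound 2 to compound 4 (0.01 log units; within the scatter). Compound 4 is therefore expected to give about 60000 nM in this assay, with a range from 30000 nM to 120000 nM.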

Compound 4, half-maximal inhibitory concentration: 5610 nM
Compound 4: the middle estimate sits 11-fold (1.03 log units) above what was measured; the whole stated range lies above it.
By their numbers in this assay, from the lowest: compound 4; then compounds 3, 2 and 1 (each within the scatter of the next).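

This position is not as indifferent as the earlier swaps suggested: in this assay, bringing in 2-chloro-5-nitrophenyl gives an 11-fold lower number from compound 2 to compound 4 (1.02 log units; beyond the scatter), and the same change gives a 9.4-fold lower number from compound 3 to compound 4 (0.97 log units; beyond the scatter) and a 15-fold lower number from compound 1 to compound 4 (1.19 log units; beyond the scatter). Among these compounds, the aryl group on the carbon with a double bond to nitrogen can therefore move the number well beyond the scatter, and compound 4 is the one compound of the four whose steps to all the others are printed as beyond it, making it the most potent of this small set. No measurement available here explains why this one group stands apart from the other three.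

The chlorine and the nitro group enter together in compound 4, and the compounds shown do not tell whether either one alone would give a step of this size, or whether the two are needed together. Also open, going by these compounds, is whether the low number would hold with an amine or a carboxylic acid in place of the nitro group, or with bromine in place of the chlorine.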